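The source may hold more compounds than are shown below. What is called first, only, known or untested is meant among the compounds shown, and "the series" means these compounds.

Compound 1 `COc1cc2c(Nc3nc4ccc(C(=O)Nc5c(C)cccc5C)cc4s3)ncnc2cc1OCCCN1CCCC1` gives > 100000 nM in a functional assay on NCI-H661 cells (Homo sapiens) for cytotoxicity, read by WST assay, with a stated time of 72 h (a lower number here means a stronger inhibitor, a higher number a weaker inhibitor), which is a limit of the assay rather than a number.
Compound 2 `COc1cc2c(Nc3nc4ccc(C(=O)Nc5c(C)cccc5C)cc4s3)ncnc2cc1OCCCN1CCC(C)CC1` gives 72300 nM in this assay.

Compound 1 stands only at a limit (the limit of > 100000 nM in this assay, at which 1 of the 2 values shown sits), so its place on the scale is not fixed by a number. Compound 3 `COc1cc2c(Nc3nc4ccc(C(=O)Nc5c(C)cc(C)cc5C)cc4s3)ncnc2cc1OCCCN1CCCC1` differs from compound 1 by methyl in place of hydrogen on an aromatic carbon. Among the compounds with values here, the single measured step, an at least 1.3-fold lower number from compound 1 to compound 2 (0.14 log units; that floor lies within the scatter), concerns a change at the other end of the shared core, on the chain carrying the saturated ring, and so does not bear on the ring that receives the new methyl; no measured step here addresses a methyl on that ring. Both measured compounds sit at or close to the ceiling of the assay. Compound 3 is therefore expected to remain at or near that ceiling, with a number no higher from compound 1 to compound 3 (the limit leaves the size open) expected to show no step beyond the scatter. Compound 3 is estimated at 100000 nM, ranging from 40000 nM to 300000 nM.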

Compound 3, half-maximal inhibitory concentration: 9600 nM
For compound 3 the middle estimate is 10-fold (1.02 log units) above the measured one; measured number outside the range, below it.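

In this assay, going from 2,6-dimethylphenyl to 2,4,6-trimethylphenyl gives an at least 10-fold lower number from compound 1 to compound 3 (1.01 log units; beyond the scatter). A single methyl on this aromatic carbon, para to a large group and meta to two methyl groups, is therefore enough to produce a step beyond the scatter, which the change on the chain did not show with an at least 1.3-fold lower number from compound 1 to compound 2 (0.14 log units; that floor lies within the scatter). Compound 1 stands at a limit and not at a number, so the new step gives only a floor for the size of the change: the limit of > 100000 nM in this assay, at which 1 of the 3 values shown sits.

The compounds shown leave open whether a chlorine, a methoxy or an ethyl on that same carbon would lower the number as the methyl does. They also leave open whether the methyl would have the same effect with 4-methylpiperidin-1-yl in place of pyrrolidin-1-yl on the chain.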